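Compound 1 to compound 3: fluoro in place of methyl

The source may hold more compounds than are shown below. What is called first, only, known or untested is meant among the compounds shown, and "the series" means these compounds.

Among the measured compounds shown here, in a functional assay on RKO cells (Homo sapiens) for inhibition, read by MTT assay, with a stated time of 48 h (on this read-out higher numbers stand for weaker inhibition and lower numbers for stronger inhibition), compound 1 (`Cc1nc(N(C)c2ccc([Se]C#N)c(C)c2)c2ccccc2n1`) gives 17 nM, the lower of the two numbers so far, and compound 2 (`COc1ccc(N(C)c2nc(C)nc3ccccc23)cc1C(=O)OCCC[Se]C#N`) gives 1140 nM. Compound 3 (`Cc1nc(N(C)c2ccc([Se]C#N)c(F)c2)c2ccccc2n1`) carries fluoro in place of methyl on an aromatic carbon, ortho to a group of 3 heavy atoms and meta to a large group: fluoro in place of methyl on an aromatic carbon. For the measured compounds named here, no measured pair shows this swap, so the expectation is only loosely grounded. In this assay a small weakening is expected, with the estimated step of a 1.8-fold higher number from compound 1 to compound 3 (0.25 log units; within the scatter). Compound 3 is estimated at 30 nM, within a range of 10 nM to 100 nM.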

Compound 3, half-maximal inhibitory concentration: 8 nM
Beside the measured number, compound 3's estimate is 3.8-fold (0.57 log units) above it, and the stated range ends above it.
By their numbers in this assay, from the lowest: compound 3; then compound 1; then compound 2.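

In this assay, fluoro in place of methyl on an aromatic carbon gives a 2.1-fold lower number from compound 1 to compound 3 (0.33 log units; beyond the scatter) as a modest gain. The methyl is therefore not needed to hold the low number, and this carbon, ortho to a group of 3 heavy atoms and meta to a large group, tolerates a swap with a small improvement. No measurement on hand accounts for the step.

The reading rests on this single pair. Open, from the compounds shown here alone, is whether chloro, methoxy or plain hydrogen on this carbon would follow fluoro or methyl.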